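This account rests on a few compounds, and the source may have more. Where it says the series, first, only, none or still open, it means among the compounds named here.

Measured so far:
compound 1 `O=C(OCc1ccccc1)N1CCN(C(=S)SCc2cn(Cc3ccccc3F)nn2)CC1` — 68300 nM
compound 2 `Fc1ccccc1Cn1cc(CSC(=S)N2CCNCC2)nn1` — 56200 nM

Both numbers come from a functional assay on PC-3 cells (Homo sapiens) for inhibition, read by MTT assay, with a stated time of 72 h; on this read-out lower numbers stand for stronger inhibition and higher numbers for weaker inhibition. On these numbers compound 1 stands level with compound 2: the step of a 1.2-fold lower number from compound 1 to compound 2 (0.08 log units; within the scatter) is within the scatter, so the two compounds cannot be told apart. Compound 3 `O=C(OCc1ccccc1)N1CCN(C(=S)SCc2cn(Cc3ccc(Cl)c(Cl)c3)nn2)CC1` has not yet been measured. It differs from compound 1 in one place: 3,4-dichlorophenyl in place of 2-fluorophenyl on a saturated chain carbon bound to an aromatic nitrogen. Within the data shown here, the only measured step, from compound 1 to compound 2, alters the amine nitrogen in the ring and leaves the 2-fluorobenzyl part untouched, so no measured step bears directly on the change made in compound 3. With nothing else to go on beyond the weak inhibition shown by compound 1, compound 3 is expected to land close to its parent, a 1.4-fold lower number from compound 1 to compound 3 (0.14 log units; within the scatter), with no step beyond the scatter expected. The estimate for compound 3 in this assay is 50000 nM, within a range from 15000 nM to 150000 nM.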

Compound 3, half-maximal inhibitory concentration: > 128000 nM
Compound 3: no number, only a limit (the forecaster's own chance of this, stated with the estimate: 20%); at least 2.5-fold (0.40 log units) between middle value and limit.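

In this assay, replacing 2-fluorobenzyl with 3,4-dichlorobenzyl gives an at least 1.8-fold higher number from compound 1 to compound 3 (0.27 log units; that floor lies within the scatter), the first step seen on the saturated chain carbon bound to an aromatic nitrogen. Compound 3 has no number, only a limit: the limit of > 128000 nM in this assay, at which 1 of the 3 values shown sits.

Going by these compounds, the change therefore shows no gain in inhibition, but the floor of the step lies within the scatter and its true size is unknown, so a real loss cannot be claimed.

This single step also removes the fluorine and adds two chlorines at once, so the compounds shown cannot separate what each contributes. Still open, on these data alone, is how a plain benzyl or a pyridylmethyl group would read in this place, and how 3,4-dichlorobenzyl would read with hydrogen in place of benzyloxycarbonyl on the amine nitrogen in the ring.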